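This account rests on a few compounds, and the source may have more. Where it says the series, first, only, none or still open, it means among the compounds named here.

In a functional assay on CFPAC-1 cells (Homo sapiens) for antiproliferative activity, read by MTT assay, with a stated time of 72 h (on this read-out higher numbers stand for weaker inhibition and lower numbers for stronger inhibition), compound 1 `CCCCc1cn(C[C@H](O)[C@H]2OC(=O)C(OCc3ccccc3)=C2OCc2ccccc2)nn1` gives 73200 nM. Compound 2 `CCCCCc1ccc(-c2cn(C[C@H](O)[C@H]3OC(=O)C(OCc4ccccc4)=C3OCc3ccccc3)nn2)cc1` gives 9890 nM, the lowest of the two numbers shown. Compound 3 `COc1ccc(-c2cn(C/C=C3\OC(=O)C(OCc4ccccc4)=C3OCc3ccccc3)nn2)cc1` gives only a limit of the assay, > 100000 nM. Exchanging butyl for 4-pentylphenyl gave a 7.4-fold lower number from compound 1 to compound 2 (0.87 log units; beyond the scatter). Compound 4 `CCCCCCCCCCc1cn(C[C@H](O)[C@H]2OC(=O)C(OCc3ccccc3)=C2OCc2ccccc2)nn1` differs from compound 2 by decyl in place of 4-pentylphenyl on an aromatic carbon. The only measured step that bears on this swapped a short chain for the ring-bearing group and was modest; the reverse direction, toward a longer chain without a ring, has no direct counterpart among the compounds shown. Compound 4 is therefore expected to fall between compound 1 and compound 2. The expected step is a 2.5-fold higher number from compound 2 to compound 4 (0.40 log units; beyond the scatter). Compound 4 is estimated at 25000 nM, with a range from 7000 nM to 90000 nM.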

Compound 4, half-maximal inhibitory concentration: 40300 nM
For compound 4 the middle estimate is 1.6-fold (0.21 log units) below the measured one, within the range that was stated.
By their numbers in this assay, from the lowest: compound 2; then compounds 4 and 1 (each within the scatter of the next). At a limit, above all of these: compound 3.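

At this aromatic carbon of the five-membered ring, a long chain without a ring does not match 4-pentylphenyl: decyl in its place gives a 4.1-fold higher number from compound 2 to compound 4 (0.61 log units; beyond the scatter). Lengthening butyl to decyl gives a 1.8-fold lower number from compound 1 to compound 4 (0.26 log units; within the scatter), so among these compounds the added chain alone makes no readable difference. It is the group carrying the six-membered aromatic ring that stands apart here. As far as these compounds go, whether a plain phenyl, or a phenyl bearing an amine, would serve as well remains open. Nothing among the data shown accounts for the gap between the ring-bearing group and decyl.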